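Swapping Methoxy for Hydroxy in a Cytotoxicity Test

The source may report more compounds than this note shows. Statements on the series, on what has been measured and on what is new or still open speak of the compounds shown alone.

In a functional assay on PC-3 cells (Homo sapiens) for cytotoxicity, read by MTT assay, with a stated time of 72 h (a higher number here means a weaker inhibitor, a lower number a stronger inhibitor), compound 2 `COc1ccc(/C=N/NC(=O)Nc2cc3c(Nc4ccc(F)c(Cl)c4)ncnc3cc2O[C@H]2CCOC2)cc1` gives 34100 nM and so stands within the scatter of compound 1 `O=C(N/N=C/c1cccc(Cl)c1Cl)Nc1cc2c(Nc3ccc(F)c(Cl)c3)ncnc2cc1O[C@H]1CCOC1` at 27400 nM while compound 3 `CC(C)(C)c1cc(/C=N/NC(=O)Nc2cc3c(Nc4ccc(F)c(Cl)c4)ncnc3cc2O[C@H]2CCOC2)cc(C(C)(C)C)c1O` reads lower at 13100 nM and lies beyond the scatter. Compound 4 `O=C(N/N=C/c1ccc(O)cc1)Nc1cc2c(Nc3ccc(F)c(Cl)c3)ncnc2cc1O[C@H]1CCOC1` carries one change from compound 2, counted as hydrogen in place of methyl on an oxygen on an aromatic ring and in words hydrogen in place of methyl on an oxygen on an aromatic ring. For the measured compounds named here, one measured step bears on this part of the molecule: a 1.2-fold higher number from compound 1 to compound 2 (0.10 log units; within the scatter) stays within the scatter even though it swaps 2,3-dichlorophenyl for 4-methoxyphenyl. No step beyond the scatter is expected in this assay and the estimated move is a 1.1-fold lower number from compound 2 to compound 4 (0.06 log units; within the scatter) with no firm direction. For compound 4 the estimated value is 30000 nM with an expected range from 15000 nM to 60000 nM.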

Compound 4, half-maximal inhibitory concentration: 4890 nM
Compound 4: the middle estimate sits 6.1-fold (0.79 log units) above what was measured; measured number outside the range, below it.
By their numbers in this assay, from the lowest: compound 4; then compound 3; then compounds 1 and 2 (each within the scatter of the next).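

In this assay the hydrogen in place of methyl on the oxygen gives a 7.0-fold lower number from compound 2 to compound 4 (0.84 log units; beyond the scatter) and shows that this position can respond to a change of a single carbon. The earlier swap to 4-methoxyphenyl stayed within the scatter, whereas 4-hydroxyphenyl in place of 2,3-dichlorophenyl gives a 5.6-fold lower number from compound 1 to compound 4 (0.75 log units; beyond the scatter) and clearly separates the two compounds. No measurement shown here explains this difference. On these data alone, whether an amine or a carboxylic acid at this place would read like the hydroxy or like the methoxy stays open, as does the effect of a longer chain on the oxygen.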